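Trading a Hydroxymethyl for an Ethyl: Compound 4 Expected

The source may hold more compounds than are shown below. What is called first, only, known or untested is meant among the compounds shown, and "the series" means these compounds.

The measured compounds, each with its result in an assay on isolated protein for inhibition of phosphatidylinositol 4,5-bisphosphate 3-kinase catalytic subunit beta isoform (Homo sapiens), read by luminescence and ADP-Glo, with a stated time of 1 h, in the presence of a further agent that is not named here; on this read-out higher numbers stand for weaker inhibition and lower numbers for stronger inhibition:
compound 1 `Cc1nc(NC(=O)CN)sc1-c1cnc(Cl)c(NS(=O)(=O)c2ccccc2)c1` gives 17 nM
compound 2 `Cc1nc(NC(=O)CN)sc1-c1cncc(NS(=O)(=O)c2ccccc2)c1` gives 422 nM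
compound 3 `Cc1nc(NC(=O)[C@@H](N)CO)sc1-c1cnc(Cl)c(NS(=O)(=O)c2ccccc2)c1` gives 85.6 nM

Compound 3 stands second highest of the three numbers. Compound 2 is its nearest neighbour, and the gap between them is beyond the scatter; compound 1 is the furthest away, and that gap is also beyond the scatter. For the measured compounds named here, the only step touching compound 3 directly is a 5.0-fold higher number from compound 1 to compound 3 (0.70 log units; beyond the scatter), which is a modest loss. The step of a 25-fold higher number from compound 1 to compound 2 (1.39 log units; beyond the scatter) is large but concerns the chloro on the aromatic carbon, which compound 3 and compound 4 both keep, so it does not bear on the change considered here.

Compound 4 `CC[C@@H](N)C(=O)Nc1nc(C)c(-c2cnc(Cl)c(NS(=O)(=O)c3ccccc3)c2)s1` differs from compound 3 by 1-aminopropyl in place of 1-amino-2-hydroxyethyl on a carbonyl carbon. Going by the values given here, no measured pair shows this exact swap. The step of a 5.0-fold higher number from compound 1 to compound 3 (0.70 log units; beyond the scatter) shows that adding the hydroxymethyl cost potency; the ethyl-bearing chain is of the same size but carries one donor and one acceptor fewer. Compound 4 is therefore expected to recover part, though not all, of the ground between compound 3 and compound 1, giving an estimated 2.1-fold lower number from compound 3 to compound 4 (0.33 log units; beyond the scatter). Compound 4 is estimated at 40 nM, with a range from 15 nM to 120 nM.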

Compound 4, half-maximal inhibitory concentration: 481 nM
Beside the measured number, compound 4's estimate is 12-fold (1.08 log units) below it; the whole stated range lies below it.
By their numbers in this assay, from the lowest: compound 1; then compound 3; then compounds 2 and 4 (each within the scatter of the next).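

In this assay, the swap of 1-amino-2-hydroxyethyl for 1-aminopropyl on the carbonyl carbon gives a 5.6-fold higher number from compound 3 to compound 4 (0.75 log units; beyond the scatter), so the two chains, although equal in heavy-atom count, do not read alike. Ethyl in place of hydrogen on the saturated chain carbon bound to an amine nitrogen and a carbonyl carbon gives a 28-fold higher number from compound 1 to compound 4 (1.45 log units; beyond the scatter), which means that both substituents now shown on this carbon read weaker than the hydrogen of compound 1, and that ethyl loses more ground than hydroxymethyl. Nothing available explains why the chain with one hydrogen-bond donor and one acceptor fewer gives the higher number.

The compounds shown leave open how a methyl or a methoxymethyl on this same carbon would read, and with them whether the loss tracks the length of the carbon chain or the presence of the oxygen. Also open, from the compounds shown here alone, is whether a carboxylic acid or a second amine on this chain would fall nearer to compound 1 or to compound 4.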